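This account rests on a few compounds, and the source may have more. Where it says the series, first, only, none or still open, it means among the compounds named here.

Working notes on a small set of purine-derived benzyl chlorides tested for growth inhibition.

Compound 1 `ClCc1ccccc1Cn1cnc2c(Cl)nc(Cl)nc21` gives 510 nM in a functional assay on OVCAR-3 cells (Homo sapiens) for cytotoxicity, read by sulforhodamine B assay, with a stated time of 48 h; on this read-out lower numbers stand for stronger inhibition of growth and higher numbers for weaker inhibition of growth. Compound 2 `ClCc1ccc(Cn2cnc3nc(Cl)nc(Cl)c32)cc1` gives 720 nM in this assay, and compound 3 `ClCc1cccc(Cn2cnc3c(Cl)nc(Cl)nc32)c1` gives 3230 nM. Among these three numbers compound 2 stands second highest; the gap to compound 1 is within the scatter, so nothing separates the two, whereas compound 3 gives a clearly higher number than compound 2, a gap beyond the scatter. Among the measured compounds shown here, the three compounds differ in where the chloromethyl group sits on the benzyl ring and in how the purine is attached, so no single-point step between measured compounds is available.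

Compound 4 `ClCc1ccc(Cn2cnc3ncnc(Cl)c32)cc1` is not yet measured in this assay. It differs from compound 2 by hydrogen in place of chloro on an aromatic carbon; the change sits on an aromatic carbon of a six-membered aromatic ring with two nitrogens, between two ring nitrogen atoms, meta to a chloro group. For the measured compounds named here, no measured pair shows the effect of removing a chloro at this place, so the expectation rests only on the general range of the set. A moderate rise in the number, toward weaker growth inhibition, is expected, as a 2.8-fold higher number from compound 2 to compound 4 (0.44 log units; beyond the scatter). The estimated value for compound 4 is 2000 nM, with a range from 600 nM to 7000 nM.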

Compound 4, concentration for total growth inhibition: 3380 nM
The estimate for compound 4 lay 1.7-fold (0.23 log units) below the measured number; low and high end bracket the measured number.
By their numbers in this assay, from the lowest: compounds 1 and 2 (each within the scatter of the next); then compounds 3 and 4 (each within the scatter of the next).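

In this assay, among the compounds shown here, this is the first comparison that isolates a single place: hydrogen in place of chloro on the aromatic carbon between two ring nitrogen atoms gives a 4.7-fold higher number from compound 2 to compound 4 (0.67 log units; beyond the scatter). This position is therefore not indifferent to the change, and within this pair the chloro goes with the stronger growth inhibition, a link that compounds 1, 2 and 3 could not show while they differed from one another in more than one place. The chloromethyl group and the other chloro are common to the pair, but the data at hand offer no explanation for the size of this step.

On these data alone, it remains open whether another group at this position, such as an amine, a methoxy group or a thiol, would give a number close to that of compound 2, close to that of compound 4 or outside that span. As far as these compounds go, it is also open whether the same exchange would give a step of similar size on the benzyl arrangements of compound 1 and compound 3.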